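This account rests on a few compounds, and the source may have more. Where it says the series, first, only, none or still open, it means among the compounds named here.

Measured so far: compound 1 `CCNC(=O)Nc1ccc(-c2nc3n(Cc4c(F)cccc4F)cc(C(=O)OCC)c(=O)n3c2CN(CC(=O)NCc2cn(CCN=[N+]=[N-])nn2)Cc2ccccc2)cc1` at 724 nM; compound 2 `CCNC(=O)Nc1ccc(-c2nc3n(Cc4c(F)cccc4F)cc(C(=O)OCC)c(=O)n3c2CN(CC(=O)NCc2cn(CCOCCOCCOCCN=[N+]=[N-])nn2)Cc2ccccc2)cc1` at 724 nM; compound 3 `CCNC(=O)Nc1ccc(-c2nc3n(Cc4c(F)cccc4F)cc(C(=O)NCc4cn(CCOCCOCCOCCN=[N+]=[N-])nn4)c(=O)n3c2CN(C)Cc2ccccc2)cc1` with only a limit, < 10000 nM.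

The study reads antagonism in a functional assay on CHO cells for antagonist activity at Gonadotropin-releasing hormone receptor (Homo sapiens), read by a luciferase reporter, with a stated time of 30 min; a lower number here means a stronger inhibitor, a higher number a weaker inhibitor. Compound 2 `CCNC(=O)Nc1ccc(-c2nc3n(Cc4c(F)cccc4F)cc(C(=O)OCC)c(=O)n3c2CN(CC(=O)NCc2cn(CCOCCOCCOCCN=[N+]=[N-])nn2)Cc2ccccc2)cc1` gives 724 nM in this assay, and compound 1 `CCNC(=O)Nc1ccc(-c2nc3n(Cc4c(F)cccc4F)cc(C(=O)OCC)c(=O)n3c2CN(CC(=O)NCc2cn(CCN=[N+]=[N-])nn2)Cc2ccccc2)cc1` gives 724 nM. The two differ by one change, (azido in place of 2-(2-(2-azidoethoxy)ethoxy)ethoxy on a saturated chain carbon, two bonds along the chain from an aromatic nitrogen), and that change made no change at the digits printed from compound 2 to compound 1 (within the scatter). Compound 3 `CCNC(=O)Nc1ccc(-c2nc3n(Cc4c(F)cccc4F)cc(C(=O)NCc4cn(CCOCCOCCOCCN=[N+]=[N-])nn4)c(=O)n3c2CN(C)Cc2ccccc2)cc1` reaches only a limit in this assay, < 10000 nM, and the record carries (the limit of < 10000 nM in this assay, at which 1 of the 3 values shown sits). How the core of compound 3 differs from that of compound 2 is not broken down here.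

Compound 4 `CCNC(=O)Nc1ccc(-c2nc3n(Cc4c(F)cccc4F)cc(C(=O)NCc4cn(CCN=[N+]=[N-])nn4)c(=O)n3c2CN(C)Cc2ccccc2)cc1` is not yet measured in this assay. It stands to compound 3 as compound 1 stands to compound 2: the difference is azido in place of 2-(2-(2-azidoethoxy)ethoxy)ethoxy on a saturated chain carbon, two bonds along the chain from an aromatic nitrogen, the same kind of change, at the same place. On that footing, and resting on the unchanged result of the step from compound 2 to compound 1, the expected step from compound 3 to compound 4 is a step that the limit leaves unreadable from compound 3 to compound 4, that is, a value much like that of compound 3. Since compound 3 is known only as a limit, the estimate for compound 4 is wide: a middle value of 3000 nM is expected, between 600 nM and 10000 nM, with a real chance that this assay again returns only a limit for compound 4.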

Compound 4, half-maximal inhibitory concentration: < 10000 nM
Compound 4: a limit, no number; the forecaster's own chance of this, stated with the estimate: 50%; the middle value does not contradict the limit.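

Compound 4 gives < 10000 nM in this assay, which is a limit and not a number, and compound 3 is likewise known only as a limit, so no step can be read from one to the other. What stays open is whether azido in place of 2-(2-(2-azidoethoxy)ethoxy)ethoxy changes anything on the core of compound 3, as the unchanged result from compound 2 to compound 1 cannot be tested against two limits: the limit of < 10000 nM in this assay, at which 2 of the 4 values shown sit.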